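Adding a hydroxy group to compound 2: working notes

The compounds below may be only part of what the source reports. "The series", "measured", "known", "first", "only" and "open" are said of these compounds alone.

Measured so far in a functional assay on cells (Neutrophil, Homo sapiens) for inhibition, read by chemiluminescence, with a stated time of 5 min; on this read-out higher numbers stand for weaker inhibition and lower numbers for stronger inhibition:
- compound 1 `O=c1cc(-c2cccc(O)c2)oc2cccc(O)c12`: 14500 nM
- compound 2 `O=c1cc(-c2ccc(O)cc2)oc2cccc(O)c12`: 18000 nM

In this assay compound 2 stands at 18000 nM, within the usual scatter of compound 1 at 14500 nM, so these two values cannot be told apart. Both compounds are weak inhibitors on this read-out.

The next compound is compound 3 `O=c1cc(-c2ccc(O)c(O)c2)oc2cccc(O)c12`, which differs from compound 2 as follows: hydroxy in place of hydrogen on an aromatic carbon. The new hydroxy replaces hydrogen on an aromatic carbon, ortho to a hydroxy group. Among the measured compounds shown here, no single-change step has yet been measured, so its size cannot be read from the data. Compound 3 carries both of the hydroxy groups that separate compound 1 (14500 nM) from compound 2 (18000 nM). For the measured compounds named here, a moderate step towards a lower number in this assay, beyond the scatter, is expected, though this rests on only two values. The estimated step is a 4.5-fold lower number from compound 2 to compound 3 (0.65 log units; beyond the scatter). For compound 3 the expected value is 4000 nM, with an estimated range of 1200 nM to 12000 nM.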

Compound 3, half-maximal inhibitory concentration: 1600 nM
Beside the measured number, compound 3's estimate is 2.5-fold (0.40 log units) above it; low and high end bracket the measured number.
By their numbers in this assay, from the lowest: compound 3; then compounds 1 and 2 (each within the scatter of the next).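

In this assay, hydroxy in place of hydrogen on an aromatic carbon, ortho to a hydroxy group, gives an 11-fold lower number from compound 2 to compound 3 (1.05 log units; beyond the scatter); the corresponding change on the other single-hydroxy compound gives a 9.1-fold lower number from compound 1 to compound 3 (0.96 log units; beyond the scatter). Compound 1 and compound 2 each carry one of these two hydroxy groups and cannot be told apart, so moving a single hydroxy group on this ring showed no difference, whereas compound 3, with both groups in place, stands clearly lower than either and is the strongest inhibitor of the three on this read-out. Nothing available accounts for the size of these steps.

The compounds shown leave open whether the gain needs a hydroxy group at this position specifically, since a methoxy group, a fluorine atom or an amine there would test that directly. They also leave open whether the two hydroxy groups must stay ortho to each other and whether the hydroxy group on the other part of the core contributes to the value at all.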